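Removing the isopropyl from the aryl ether of compound 3

The source may hold more compounds than are shown below. What is called first, only, known or untested is meant among the compounds shown, and "the series" means these compounds.

Measured so far in an assay on HEK293 cells for displacement of a labelled ligand from 5-hydroxytryptamine receptor 6 (Homo sapiens), read by radioligand binding, with a stated time of 1 h; a higher number here means a weaker inhibitor, a lower number a stronger inhibitor:
- compound 1 `CN1CCN(c2nc(N)nc(COc3ccccc3Cl)n2)CC1` gives 129 nM
- compound 2 `CN1CCN(c2nc(N)nc(COc3cccc(Cl)c3)n2)CC1` gives 148 nM
- compound 3 `Cc1ccc(C(C)C)c(OCc2nc(N)nc(N3CCN(C)CC3)n2)c1` gives 11 nM

Compound 3 stands lowest of the three numbers in this assay, and its steps to compound 1 and to compound 2 are both beyond the scatter; it is therefore the strongest binder of the set. Among the compounds with values here, the one measured step, a 1.1-fold higher number from compound 1 to compound 2 (0.06 log units; within the scatter), concerns only where the chlorine sits on the aryl ether and lies within the scatter, so it says nothing about the change considered here.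

Compound 4 `Cc1cccc(OCc2nc(N)nc(N3CCN(C)CC3)n2)c1` differs from compound 3 by hydrogen in place of isopropyl on an aromatic carbon, on an aromatic carbon of a six-membered aromatic ring of carbon only, ortho to a large group and para to a methyl group. Within the data shown here, no measured pair in the set removes a substituent of this kind from the aryl ether, so the step has no direct precedent. Given that compound 3 carries both the isopropyl and the methyl and sits well below the chlorophenyl analogues, losing the isopropyl is expected to cost some binding, a step of a 4.1-fold higher number from compound 3 to compound 4 (0.61 log units; beyond the scatter) in this assay toward a higher number. Compound 4 is thus estimated at 45 nM, with a range from 15 nM to 150 nM.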

Compound 4, inhibition constant: 207 nM
Compound 4: middle estimate off by 4.6-fold (0.66 log units), on the low side, and the stated range ends below it.
By their numbers in this assay, from the lowest: compound 3; then compounds 1, 2 and 4 (each within the scatter of the next).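

In this assay, the aromatic carbon ortho to a large group and para to a methyl group proves highly sensitive to this change: hydrogen in place of isopropyl gives a 19-fold higher number from compound 3 to compound 4 (1.27 log units; beyond the scatter), a large step. Without the isopropyl, compound 4 no longer stands apart from the chlorophenyl analogues, with methyl in place of chloro giving a 1.4-fold higher number from compound 2 to compound 4 (0.15 log units; within the scatter) and 3-methylphenyl in place of 2-chlorophenyl giving a 1.6-fold higher number from compound 1 to compound 4 (0.21 log units; within the scatter), so on this evidence the low number of compound 3 is tied to the isopropyl and not to the methyl alone. The data shown offer no explanation for the size of the isopropyl step.

Open, from the compounds shown here alone, is whether another group at this carbon, such as ethyl, tert-butyl, cyclopropyl or methoxy, would hold the number seen for compound 3 or whether the isopropyl itself is needed. Also open, going by these compounds, is whether the isopropyl would give a step of similar size on an aryl ether carrying chloro in place of methyl, or with no methyl group at all.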